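Methoxymethyl on the Ring Nitrogen of a Deoxygenated Analogue

This account rests on a few compounds, and the source may have more. Where it says the series, first, only, none or still open, it means among the compounds named here.

Compound 3 `O=c1cc(CC(COCc2ccccc2)COCc2ccccc2)[nH]c(=O)[nH]1` sits at the edge of what can be read in a functional assay on MIA PaCa-2 cells (Homo sapiens) for antiproliferative activity, read by MTT assay, with a stated time of 72 h; on this read-out lower numbers stand for stronger inhibition and higher numbers for weaker inhibition. In this assay compound 3 gives > 100000 nM, which is a limit of the assay and not a number. Compound 1 `O=c1cc(CC(O)(COCc2ccccc2)COCc2ccccc2)[nH]c(=O)[nH]1` gives > 100000 nM in this assay, also a limit. Compound 2 `COCn1c(CC(O)(COCc2ccccc2)COCc2ccccc2)cc(=O)[nH]c1=O` gives > 100000 nM in this assay, again a limit. Compound 4 `COCn1c(CC(COCc2ccccc2)COCc2ccccc2)cc(=O)[nH]c1=O` has not been measured; it differs from compound 3 by methoxymethyl in place of hydrogen on an aromatic nitrogen. The same change appears in the step that the two limits leave unreadable from compound 1 to compound 2, which the two limits leave unreadable, and the step that the two limits leave unreadable from compound 1 to compound 3 is equally unreadable. Among the compounds with values here, the only evidence is the limit of > 100000 nM in this assay, at which 3 of the 3 values shown sit. No step beyond the scatter can be expected in either direction. Compound 4 is expected to give 150000 nM in this assay, between 50000 nM and 500000 nM, an estimated step that the limit leaves unreadable from compound 3 to compound 4.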

Compound 4, half-maximal inhibitory concentration: > 100000 nM
Compound 4 gave a limit, no number; the forecaster's own chance of this, stated with the estimate: 85%; the middle value is on the limit's open side.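

In this assay compound 4 gives only a limit, so no step can be read from compound 3 to compound 4 or from compound 2 to compound 4. The compounds shown leave open whether methoxymethyl in place of hydrogen, or hydrogen in place of hydroxy, changes activity at all, as none of the four gives a number.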